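Benzylsulfanyl versus allylsulfanyl on the shared core

A few compounds are considered here, and "the series" means these few. Any claim that something is new, unique, unknown or untested is made for them only; others in the source may bear on it.

Going by the values given here, compound 2 `C=CCSc1nc2nc(C)cc(N3CC[C@@H](C)[C@@H](N(C)c4ncnc5[nH]ccc45)C3)n2n1` stands at the higher of the two numbers so far: in a functional assay on HGC-27 cells (Homo sapiens) for inhibition, read by MTT assay, with a stated time of 72 h (on this read-out lower numbers stand for stronger inhibition and higher numbers for weaker inhibition), compound 2 gives 35200 nM. Compound 1 `Cc1cc(N2CC[C@@H](C)[C@@H](N(C)c3ncnc4[nH]ccc34)C2)n2nc(SCc3ccc(C(F)(F)F)cc3)nc2n1` carries a 4-(trifluoromethyl)benzyl group on the sulfur and in this assay compound 1 gives 9540 nM. Among the compounds with values here, the one comparable step, a 3.7-fold higher number from compound 1 to compound 2 (0.57 log units; beyond the scatter), shows that shortening the sulfur substituent to allyl weakens inhibition.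

Compound 3 `Cc1cc(N2CC[C@@H](C)[C@@H](N(C)c3ncnc4[nH]ccc34)C2)n2nc(SCc3ccc(F)cc3)nc2n1` reverses that kind of change: 4-fluorophenyl in place of vinyl on a saturated chain carbon bound to a sulfur. It restores an aryl group, though with fluorine in place of trifluoromethyl, so the step is expected to run opposite to the step from compound 1 to compound 2, and of comparable size. On that basis the step of a 2.9-fold lower number from compound 2 to compound 3 (0.47 log units; beyond the scatter) is expected in this assay. For compound 3 the estimate in this assay is 12000 nM, with a range of 4000 nM to 40000 nM.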

Compound 3, half-maximal inhibitory concentration: 26000 nM
Estimate against measurement, compound 3: 2.2-fold (0.34 log units) below, and the stated range covers the measured number.
By their numbers in this assay, from the lowest: compound 1; then compounds 3 and 2 (each within the scatter of the next).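

In this assay, the step of a 1.4-fold lower number from compound 2 to compound 3 (0.13 log units; within the scatter) shows that 4-fluorophenyl and vinyl on a saturated chain carbon bound to a sulfur cannot be told apart, so an aromatic ring at this place is not enough on its own to separate compound 3 from compound 2. The step of a 2.7-fold higher number from compound 1 to compound 3 (0.44 log units; beyond the scatter) then ties the advantage of compound 1 to the group on the aromatic ring, as fluoro in place of trifluoromethyl on an aromatic carbon gives that advantage up. Compound 1 is thus the only one of the three that stands apart, with both of its steps beyond the scatter.

Open, as far as these compounds go, is whether a nitrile, a methoxy group or a carboxylic acid on that aromatic carbon would behave like trifluoromethyl or like fluoro. Also open, from the compounds shown here alone, is how a longer chain such as phenethyl on the sulfur would read, and nothing available explains the gap from compound 1 to compound 3.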